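A few compounds are considered here, and "the series" means these few. Any claim that something is new, unique, unknown or untested is made for them only; others in the source may bear on it.

Compound 1 `Cc1nc(N)c2c(-c3ccccc3)cn([C@@H]3O[C@H](CO)[C@@H](O)[C@H]3O)c2n1`: in a functional assay on HCT-116 cells (Homo sapiens), read by MTT assay, with a stated time of 72 h (on this read-out lower numbers stand for stronger inhibition and higher numbers for weaker inhibition), compound 1 gives > 100000 nM, a limit of the assay.
Compound 2 `COc1nc(N)nc2c1c(-c1ccsc1)cn2[C@@H]1O[C@H](CO)[C@@H](O)[C@H]1O`: in this assay compound 2 gives > 20000 nM, likewise a limit.
Compound 3 `Nc1nc(N)c2c(-c3ccccc3)cn([C@@H]3O[C@H](CO)[C@@H](O)[C@H]3O)c2n1`: in this assay compound 3 gives > 20000 nM, again a limit.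

Compound 1 thus stands only at a limit, as do the two other values shown; none of the three is a number. For the measured compounds named here, the one step read between measured compounds, a step that the two limits leave unreadable from compound 1 to compound 3, cannot be sized because both ends are limits. Compound 4 `Cc1nc(N)c2c(-c3ccsc3)cn([C@@H]3O[C@H](CO)[C@@H](O)[C@H]3O)c2n1` differs from compound 1 by thiophen-3-yl in place of phenyl on an aromatic carbon. Compound 2, which also carries a thiophen-3-yl group, sits at a limit, so nothing measured points to a gain. Compound 4 is therefore expected to remain at a limit, an estimated step of a number no higher from compound 1 to compound 4 (the limit leaves the size open), giving an estimate of 100000 nM for compound 4, in the range 30000 nM to 300000 nM.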

Compound 4, half-maximal inhibitory concentration: > 20000 nM
Compound 4 ended at the assay's limit; the forecaster's own chance of this, stated with the estimate: 85%; the middle value is on the limit's open side.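

Compound 1 and compound 4 both stand at limits in this assay, and the step between them cannot be read. The compounds shown leave open whether thiophen-3-yl in place of phenyl changes inhibition at all.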